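The compounds below may be only part of what the source reports. "The series", "measured", "known", "first", "only" and "open" are said of these compounds alone.

Compound 2, with the structure `Cc1cccc(COc2ccc(/C=C/C(/C=C/c3ccccn3)=N/Oc3ncnc4ccccc34)cc2)c1`, gives the highest number among the three compounds measured in a functional assay on SMMC-7721 cells (Homo sapiens) for inhibition, read by MTT assay, with a stated time of 72 h, tested at 10 uM (on this read-out higher numbers stand for a stronger effect at the one concentration tested and lower numbers for a weaker effect), where compound 2 gives 97.5%. Compound 3, whose structure is `Cc1cccc(COc2ccc(/C=C/C(/C=C/c3ccccn3)=N/Oc3ncnc4cc(Cl)ccc34)cc2)c1`, comes nearest: in this assay compound 3 gives 95.6%, and the step of a number 1.9 percentage points lower from compound 2 to compound 3 (within the scatter) is small. Compound 1, with the structure `Cc1cccc2ncnc(O/N=C(/C=C/c3ccc(OCc4ccccc4Cl)cc3)\C=C\c3ccccn3)c12`, stands furthest away; in this assay compound 1 gives 84.7%.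

Compound 4, whose structure is `Clc1ccccc1COc1ccc(/C=C/C(/C=C/c2ccccn2)=N/Oc2ncnc3ccccc23)cc1`, differs from compound 2 in one place: 2-chlorophenyl in place of 3-methylphenyl on a saturated chain carbon bound to an oxygen on an aromatic ring. Among the measured compounds shown here, none of the measured steps makes exactly this change on its own, since compound 1 carries the 2-chlorobenzyl group but also a methyl on the shared core, so it differs from compound 2 in two places. For the measured compounds named here, the only single step known, from compound 2 to compound 3, was within the scatter. What the two values of compound 1 and compound 2 show is a lower number where the 2-chlorobenzyl group is present. Weighing this, compound 4 is expected to come out at 90%, somewhere between 78% and 98%, so that the expected step of a number 7.5 percentage points lower from compound 2 to compound 4 (within the scatter) lies within the scatter.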

Compound 4, a percentage reported as inhibition, at one concentration (the size of the read-out at that concentration, not a potency): 96.9%
Compound 4: the middle estimate sits 6.9 percentage points below what was measured; measured number inside the range.
By their numbers in this assay, from the lowest: compound 1; then compounds 3, 4 and 2 (each within the scatter of the next).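

In this assay, 2-chlorophenyl in place of 3-methylphenyl on a saturated chain carbon bound to an oxygen on an aromatic ring gives a number 0.6 percentage points lower from compound 2 to compound 4 (within the scatter) and so leaves these two groups indistinguishable at this position. The 2-chlorobenzyl group alone therefore does not go with a lower number, which compound 1 could not show, as it also carries a methyl on the shared core. With that group held constant, hydrogen in place of methyl on an aromatic carbon gives a number 12.2 percentage points higher from compound 1 to compound 4 (beyond the scatter) and is a modest but real step. Going by these compounds, whether the number would hold with a very different group on this chain carbon, such as an amine or a carboxylic acid, stays open. No measurement here explains either step.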